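Swapping the aryl group on the hydrazone end of the series

This account rests on a few compounds, and the source may have more. Where it says the series, first, only, none or still open, it means among the compounds named here.

Of the compounds shown here, two have numbers so far in a functional assay on MCF7 cells (Homo sapiens) for cytotoxicity, read by MTT assay, with a stated time of 72 h; on this read-out lower numbers stand for stronger inhibition and higher numbers for weaker inhibition. Compound 1 (`O=C(N/N=C/c1cccc(Br)c1)Nc1cc2c(Nc3ccc(F)c(Cl)c3)ncnc2cc1O[C@H]1CCOC1`) gives 12400 nM, and compound 2 (`COc1cc2ncnc(Nc3ccc(F)c(Cl)c3)c2cc1NC(=O)N/N=C/c1ccc(F)cc1`) gives 35100 nM. Compound 2 therefore holds the higher of the two numbers, and the gap between them lies beyond the usual scatter. These two compounds differ in more than one place, so the gap cannot be assigned to any single change.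

Compound 3 (`COc1cc2ncnc(Nc3ccc(F)c(Cl)c3)c2cc1NC(=O)N/N=C/c1cccc(Br)c1`) is the next to be read. It follows from compound 2 by one change: 3-bromophenyl in place of 4-fluorophenyl on a carbon with a double bond to nitrogen. Among the compounds with values here, no measured pair isolates this change. Within the data shown here, the only guide is that compound 1 carries the same 3-bromophenyl and gives 12400 nM, although it differs from compound 3 elsewhere.

A modest move toward a lower number is expected in this assay, about the size of the scatter. The estimated step is a 1.8-fold lower number from compound 2 to compound 3 (0.24 log units; within the scatter). For compound 3 the estimated value is 20000 nM, with an expected range from 9000 nM to 45000 nM.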

Compound 3, half-maximal inhibitory concentration: 27100 nM
Compound 3: middle estimate off by 1.4-fold (0.13 log units), on the low side; low and high end bracket the measured number.
By their numbers in this assay, from the lowest: compound 1; then compounds 3 and 2 (each within the scatter of the next).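

In this assay, 3-bromophenyl in place of 4-fluorophenyl on a carbon with a double bond to nitrogen gives a 1.3-fold lower number from compound 2 to compound 3 (0.11 log units; within the scatter), so with methyl held on the oxygen, this aryl swap does not separate from the scatter. Within the data shown here, with 3-bromophenyl held fixed, methyl in place of oxolan-3-yl on an oxygen on an aromatic ring gives a 2.2-fold higher number from compound 1 to compound 3 (0.34 log units; beyond the scatter), and of the two one-place steps now available, only this change at the oxygen reads beyond the scatter. No supporting measurement on these compounds bears on the size of either step.

As far as these compounds go, the aryl swap has been read only with methyl on the oxygen, so its size with oxolan-3-yl there remains open. Also open, from the compounds shown here alone, is whether a longer chain ending in an amine on that oxygen, or a carboxylic acid or nitrile on the aryl ring at the hydrazone end, would give a step beyond the scatter in this assay.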